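The source may report more compounds than this note shows. Statements on the series, on what has been measured and on what is new or still open speak of the compounds shown alone.

Measured compounds:
- compound 1 `O=C(CN1CN(c2ccccc2)C2(CCN(C(=O)c3ccc(C4CCCCC4)cc3)CC2)C1=O)NCCCCO`, giving 10300 nM in an assay on HEK293 cells for displacement of a labelled ligand from NPC1-like intracellular cholesterol transporter 1 (Homo sapiens); a higher number here means a weaker inhibitor, a lower number a stronger inhibitor
- compound 2 `CC(C)(C)OC(=O)NC1CCCN(C(=O)CN2CN(c3ccccc3)C3(CCN(C(=O)c4ccc(C5CCCCC5)cc4)CC3)C2=O)C1`, giving 4400 nM in this assay
- compound 3 `CC(C)(C)c1ccc(C(=O)N2CCC3(CC2)C(=O)N(CC(=O)NCCCCO)CN3c2ccccc2)cc1`, giving 19200 nM in this assay

Compound 1 stands second highest of these three numbers. Its nearest neighbour is compound 3, where the change a 1.9-fold higher number from compound 1 to compound 3 (0.27 log units; within the scatter) lies within the scatter. For the measured compounds named here, its furthest neighbour is compound 2, whose lower number lies beyond the scatter; no single-place step joins these two.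

Compound 4 `CC1(C)CC(OC(=O)CN2CN(c3ccccc3)C3(CCN(C(=O)c4ccc(C5CCCCC5)cc4)CC3)C2=O)CC(C)(C)N1` has not yet been measured. It differs from compound 1 in one place: (2,2,6,6-tetramethylpiperidin-4-yl)oxy in place of (4-hydroxybutyl)amino on a carbonyl carbon.

No measured step changes this part of the core, since the one step shown alters a group on an aromatic carbon and is small. Compound 2 does carry a ring-containing group at the same carbonyl carbon, and its lower number is the only hint that a larger group there may be tolerated. The expectation is therefore a small to moderate step in this assay towards a lower number, a 1.6-fold lower number from compound 1 to compound 4 (0.20 log units; within the scatter), with a wide range. Compound 4 is estimated at 6500 nM, between 2000 nM and 20000 nM.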

Compound 4, half-maximal inhibitory concentration: 600 nM
Beside the measured number, compound 4's estimate is 11-fold (1.03 log units) above it; measured number below the stated range.
By their numbers in this assay, from the lowest: compound 4; then compound 2; then compounds 1 and 3 (each within the scatter of the next).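

In this assay, the group on this carbonyl carbon turns out to have a strong hold on the number, giving a 17-fold lower number from compound 1 to compound 4 (1.23 log units; beyond the scatter). For the compounds shown here, the one earlier step from compound 1, on an aromatic carbon, gave only a 1.9-fold higher number from compound 1 to compound 3 (0.27 log units; within the scatter). This single replacement changes several things at once: an open chain gives way to a six-membered non-aromatic ring, the group grows larger, and the link to the carbonyl carbon changes from nitrogen to oxygen, and nothing shown explains why the number falls so far.

As far as these compounds go, it remains open which of these features carries the step. A (2,2,6,6-tetramethylpiperidin-4-yl)amino group would separate the linking atom from the ring, while a plain cyclohexyloxy group would show what the ring nitrogen and the methyl groups contribute.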